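Swapping the aryl group on the triazole of compound 1

This account rests on a few compounds, and the source may have more. Where it says the series, first, only, none or still open, it means among the compounds named here.

Compound 1 `COc1cccc(-n2cc(CO/N=C3\CC[C@]4(C)[C@@H](CC/C=C(\C)CC/C=C(\C)CCC=C(C)C)[C@](C)(O)CC[C@H]4C3(C)C)nn2)c1` is a terpenoid oxime ether that carries a 3-methoxyphenyl on its triazole ring. In a functional assay on DU-145 cells (Homo sapiens) for cytotoxicity, read by MTT assay, with a stated time of 48 h (a lower number here means a stronger inhibitor, a higher number a weaker inhibitor), compound 1 gives 30500 nM, the highest of the two numbers recorded so far; its nearest neighbour is compound 2 `CC(C)=CCC/C(C)=C/CC/C(C)=C/CC[C@@H]1[C@@]2(C)CC/C(=N\OCc3cn(-c4cccc(Br)c4)nn3)C(C)(C)[C@@H]2CC[C@@]1(C)O`, which gives 14600 nM. Going by the values given here, the only measured step, a 2.1-fold lower number from compound 1 to compound 2 (0.32 log units; beyond the scatter), comes from bromo in place of methoxy on an aromatic carbon.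

Compound 3 `CC(C)=CCC/C(C)=C/CC/C(C)=C/CC[C@@H]1[C@@]2(C)CC/C(=N\OCc3cn(-c4ccncc4)nn3)C(C)(C)[C@@H]2CC[C@@]1(C)O` differs from compound 1 as follows: pyridin-4-yl in place of 3-methoxyphenyl on an aromatic nitrogen. Among the compounds with values here, no measured step exchanges the whole aryl group, so the step from compound 1 to compound 2 bears on this change only loosely, and it is itself modest. On that basis a small step is expected, around a 1.2-fold lower number from compound 1 to compound 3 (0.09 log units; within the scatter), perhaps within the scatter. Compound 3 is estimated at 25000 nM, with a range from 8000 nM to 70000 nM.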

Compound 3, half-maximal inhibitory concentration: 17400 nM
Estimate against measurement, compound 3: 1.4-fold (0.16 log units) above, and the stated range covers the measured number.
By their numbers in this assay, from the lowest: compounds 2, 3 and 1 (each within the scatter of the next, the first and the last beyond it).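

Here the whole aryl group on the triazole changes, not just one substituent on it, and pyridin-4-yl gives a 1.8-fold lower number from compound 1 to compound 3 (0.24 log units; within the scatter) and a 1.2-fold higher number from compound 2 to compound 3 (0.08 log units; within the scatter) in the second comparison. In this assay compound 3 therefore cannot be told apart from compound 1 or from compound 2, even though those two differ from each other beyond the scatter, so among these three compounds a ring containing nitrogen does about as well here as a carbon-only ring. Nothing available explains these numbers.

Whether the place of the ring nitrogen matters stays open, since pyridin-3-yl is not among the compounds shown. As far as these compounds go, what an amine or a carboxylic acid on the aryl ring would do, or a plain butyl chain in place of the ring, also stays open.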